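Moving one chlorine on the weakest compound

The source may report more compounds than this note shows. Statements on the series, on what has been measured and on what is new or still open speak of the compounds shown alone.

Measured so far in a functional assay on T98G cells (Homo sapiens) for inhibition, read by MTT assay, with a stated time of 72 h; a lower number here means a stronger inhibitor, a higher number a weaker inhibitor (lower means stronger):
Compound 1 `CC1(C)CC(NC(=O)Nc2cccc(Cl)c2)c2cc(Br)ccc2O1` gives 67000 nM
Compound 2 `CC1(C)CC(NC(=S)Nc2cccc([N+](=O)[O-])c2)c2cc(Br)ccc2O1` gives 4000 nM
Compound 3 `CC1(C)CC(NC(=S)Nc2cccc(Cl)c2)c2cc(Br)ccc2O1` gives 9000 nM

Compound 1 (67000 nM) has the highest number of the three, which makes it the weakest inhibitor in this small set. Compound 4 `CC1(C)CC(NC(=O)Nc2ccccc2Cl)c2cc(Br)ccc2O1` keeps the core of compound 1 and makes one change, 2-chlorophenyl in place of 3-chlorophenyl on an amide-type nitrogen and nothing else. Among the compounds with values here, only one measured step touches this aromatic ring, a 2.3-fold higher number from compound 2 to compound 3 (0.35 log units; beyond the scatter), a modest move that swaps nitro for chloro. Within the data shown here, it does not shift a chlorine to a new place on the ring, so it bears on this change only loosely, and no measured pair shows such a shift directly. A small step at most is therefore expected, with no clear direction and probably none beyond the scatter. The expected size of the step is a 1.1-fold lower number from compound 1 to compound 4 (0.05 log units; within the scatter) in this assay and it remains uncertain. Compound 4 is estimated at 60000 nM (estimated range 25000 nM to 150000 nM).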

Compound 4, half-maximal inhibitory concentration: 11000 nM
For compound 4 the middle estimate is 5.5-fold (0.74 log units) above the measured one, and the stated range ends above it.
By their numbers in this assay, from the lowest: compound 2; then compounds 3 and 4 (each within the scatter of the next); then compound 1.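

Moving the chlorine, with the atoms otherwise unchanged, gives a 6.1-fold lower number from compound 1 to compound 4 (0.78 log units; beyond the scatter) in this assay, so where the chlorine sits on this aromatic ring matters, which the earlier swap of nitro for chloro could not show. The 3-chlorophenyl and 2-chlorophenyl groups have the same heavy atoms, the same ring, no hydrogen-bond donors or acceptors and no net charge, so these counts alone do not separate the two compounds. Nothing available here gives a reason for this step.

The compounds shown leave open whether the same shift of chlorine would carry over to thiocarbonyl compounds such as compound 3. They also leave open how a methoxy group or an amine would compare with the chlorine on the 2-chlorophenyl ring.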